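This account rests on a few compounds, and the source may have more. Where it says the series, first, only, none or still open, it means among the compounds named here.

In a functional assay on A2780 cells (Homo sapiens) for antiproliferative activity, read by CellTiter-Glo, with a stated time of 4 days (on this read-out higher numbers stand for weaker inhibition and lower numbers for stronger inhibition), compounds that share one core and differ in the group on a carbonyl carbon have been compared. Compound 1 `COCC(=O)N[C@@H](C)c1ccc(NC(=O)[C@H]2C[C@@H]2c2cccnc2)cc1`, carrying methoxymethyl, gives 30 nM. Compound 2 `C[C@H](NC(=O)c1ccccc1)c1ccc(NC(=O)[C@H]2C[C@@H]2c2cccnc2)cc1`, carrying phenyl, gives 1 nM. Compound 3 `C[C@H](NC(=O)c1ccc(F)cc1)c1ccc(NC(=O)[C@H]2C[C@@H]2c2cccnc2)cc1`, carrying 4-fluorophenyl, gives 2 nM, which is far under the number for compound 1 and within the scatter of the number for compound 2.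

Compound 4 `C[C@H](NC(=O)c1ncccn1)c1ccc(NC(=O)[C@H]2C[C@@H]2c2cccnc2)cc1` has pyrimidin-2-yl in place of the 4-fluorophenyl of compound 3: pyrimidin-2-yl in place of 4-fluorophenyl on a carbonyl carbon. Two measured steps show that replacing methoxymethyl with an aromatic ring made a large difference: a 30-fold lower number from compound 1 to compound 2 (1.48 log units; beyond the scatter) and a 15-fold lower number from compound 1 to compound 3 (1.18 log units; beyond the scatter). Adding fluoro made little difference: a 2.0-fold higher number from compound 2 to compound 3 (0.30 log units; within the scatter).

Within the data shown here, compound 4 keeps a six-membered aromatic ring, but no measured compound has hetero atoms in that ring, so the evidence is indirect. A modest rise in this assay is therefore expected, smaller than the steps away from compound 1. The expected change is a 2.5-fold higher number from compound 3 to compound 4 (0.40 log units; beyond the scatter). The estimate for compound 4 is 5 nM, with an expected range of 1.5 nM to 20 nM.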

Compound 4, half-maximal inhibitory concentration: 14 nM
The estimate for compound 4 lay 2.8-fold (0.45 log units) below the measured number; the measured number falls inside the stated range.
By their numbers in this assay, from the lowest: compounds 2 and 3 (each within the scatter of the next); then compound 4; then compound 1.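

Among these compounds, earlier compounds showed only that a carbon-only aromatic ring on this carbonyl carbon gives much lower numbers than methoxymethyl, but the atoms of that ring also matter: this assay shows a 7.0-fold higher number from compound 3 to compound 4 (0.85 log units; beyond the scatter) and a 14-fold higher number from compound 2 to compound 4 (1.15 log units; beyond the scatter) when pyrimidin-2-yl, with its 2 hetero atoms, enters. A six-membered aromatic ring alone is therefore not enough to reach the lowest numbers, since pyrimidin-2-yl keeps only a small part of the gain over methoxymethyl, with a 2.1-fold lower number from compound 1 to compound 4 (0.33 log units; beyond the scatter) against the far larger step to phenyl. No measurement at hand explains the effect of exchanging these ring atoms.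

A pyridinyl ring, with a single ring nitrogen, could show whether one hetero atom is enough to raise the number. From the compounds shown here alone, how a phenyl ring bearing an amine or a carboxylic acid would behave on this carbonyl carbon also remains open.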